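Adding a chlorine to a tolerated benzothiazole-thiophene scaffold

The compounds below may be only part of what the source reports. "The series", "measured", "known", "first", "only" and "open" are said of these compounds alone.

Compounds measured for cytotoxicity:
- compound 1, `Fc1ccccc1/C=N/c1sc2c(c1-c1nc3ccccc3s1)CCC2`: 270 ug/mL
- compound 2, `Clc1ccccc1/C=N/c1sc2c(c1-c1nc3ccccc3s1)CCC2`: 123 ug/mL
- compound 3, `C(=C/c1ccccc1)\C=N\c1sc2c(c1-c1nc3ccccc3s1)CCC2`: 122 ug/mL

These three share a core in which an imine arm and a benzothiazole ring hang from a fused thiophene. In an ADME assay on cells (Rhabdomyosarcoma cell, Homo sapiens) for cytotoxicity, read by MTT assay, with a stated time of 72 h (a higher number here means that more compound is tolerated, a lower number that less compound is tolerated), compound 1 gives 270 ug/mL, compound 2 gives 123 ug/mL and compound 3 gives 122 ug/mL. Compound 3 thus has the lowest number of the three, but its value and that of compound 2 lie within the scatter of each other, so the two cannot be ranked; only compound 1 stands apart, with a 2.2-fold lower number from compound 1 to compound 3 (0.35 log units; beyond the scatter).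

Compound 4, `Clc1ccc2sc(-c3c(/N=C/C=C/c4ccccc4)sc4c3CCC4)nc2c1`, differs from compound 3 by chloro in place of hydrogen on an aromatic carbon. Among the compounds with values here, no measured step touches this ring. The closest comparison is a 2.2-fold lower number from compound 1 to compound 2 (0.34 log units; beyond the scatter), where chlorine also entered an aromatic carbon, though on the imine arm rather than on the benzothiazole. That step was modest, and the chlorine here sits in a different part of the molecule, so the expectation is a small change, if any, in this assay: a 1.2-fold lower number from compound 3 to compound 4 (0.09 log units; within the scatter) is the estimated step, leaning slightly toward less tolerance. Compound 4 is therefore expected to give about 100 ug/mL, with a likely range from 55 ug/mL to 190 ug/mL.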

Compound 4, half-maximal cytotoxic concentration: 122 ug/mL
Compound 4: middle estimate off by 1.2-fold (0.09 log units), on the low side, within the range that was stated.
By their numbers in this assay, from the lowest: compounds 3, 4 and 2 (each within the scatter of the next); then compound 1.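

In this assay, chloro in place of hydrogen on an aromatic carbon of a six-membered aromatic ring of carbon only, part of a fused or bridged system of two rings, gives no change at the digits printed from compound 3 to compound 4 (within the scatter). Within the data shown here, the earlier steps changed only the group on the carbon with a double bond to nitrogen, so this pair is the first reading on the fused ring, and it shows that this position can carry a chlorine with no detectable shift in the amount of compound tolerated. No separate measurement is available that bears on why the number stays put.

This single pair cannot show whether an amine, a carboxylic acid or a methoxy group at the same carbon would leave the reading just as undisturbed, since a lone chlorine says little about groups of a different kind. It also leaves open whether chloro on this ring would behave the same way on compound 1, which stands apart from compound 3 in this assay and carries a 2-fluorophenyl group in place of the 2-phenylethenyl group.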